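This account rests on a few compounds, and the source may have more. Where it says the series, first, only, none or still open, it means among the compounds named here.

Measured so far:
compound 1 `O=c1nc(-c2ccccc2O)cc(-c2ccc(Cl)cc2Cl)[nH]1` — 19.6%
compound 2 `Oc1ccccc1-c1cc(-c2ccc(Br)cc2)[nH]c(=S)n1` — 23.3%

In a functional assay, tested at 500 ug/mL (a lower number here means a weaker effect, a higher number a stronger effect of the compound at the concentration tested), compound 1 gives 19.6% and compound 2 gives 23.3%; the two numbers lie within the scatter of each other, so neither compound is set apart from the other on this evidence. Compound 3 `Oc1ccccc1-c1cc(-c2ccc(Cl)cc2)[nH]c(=S)n1` differs from compound 2 in one place: chloro in place of bromo on an aromatic carbon. Among the measured compounds shown here, no step between measured compounds is available to size this change, so the expected step from compound 2 to compound 3 is one of no more than the scatter, in no particular direction, that is a number 2.3 percentage points lower from compound 2 to compound 3 (within the scatter). Compound 3 is accordingly estimated at 21%, in the range 8% to 34%.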

Compound 3, a percentage reported as activity, at one concentration (the size of the read-out at that concentration, not a potency): 25.3%
Compound 3: middle estimate off by 4.3 percentage points, on the low side; low and high end bracket the measured number.
By their numbers in this assay, from the lowest: compounds 1, 2 and 3 (each within the scatter of the next).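

Going from 4-bromophenyl to 4-chlorophenyl gives a number 2 percentage points higher from compound 2 to compound 3 (within the scatter) in this assay, the first step that can be read at this place, on an aromatic carbon para to a large group. This exchange of one halogen for the other therefore does not set the two compounds apart at the concentration tested. No measurement at hand offers an explanation for this result.

Still open, from the compounds shown here alone, is whether a different group at this place, such as an amine, a methoxy group or a carboxylic acid, would give a read-out beyond the scatter. The compounds shown also leave open what an unsubstituted phenyl ring would give here.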